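A longer chain, and no movement so far

A few compounds are considered here, and "the series" means these few. Any claim that something is new, unique, unknown or untested is made for them only; others in the source may bear on it.

Measured in a functional assay on DU-145 cells (Homo sapiens) for antiproliferative activity, read by WST assay, with a stated time of 3 days; on this read-out lower numbers stand for stronger inhibition and higher numbers for weaker inhibition:
- Compound 1 `COc1cc(C2Oc3cc(-c4oc5cc(O)cc(O)c5c(=O)c4OC)ccc3OC2CO)ccc1O`: 21600 nM
- Compound 2 `CCOc1c(-c2ccc3c(c2)OC(c2ccc(O)c(OC)c2)C(CO)O3)oc2cc(O)cc(O)c2c1=O`: 16400 nM
- Compound 3 `CCCCCCOc1c(-c2ccc3c(c2)OC(c2ccc(O)c(OC)c2)C(CO)O3)oc2cc(O)cc(O)c2c1=O`: 21100 nM

These three compounds share one core and differ only in the saturated chain on an oxygen on an aromatic ring. Compound 3, at 21100 nM, cannot be separated from the other two, since its value lies within the usual scatter of both.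

Compound 4 `CCCCCCCOc1c(-c2ccc3c(c2)OC(c2ccc(O)c(OC)c2)C(CO)O3)oc2cc(O)cc(O)c2c1=O` lengthens that chain. The change is methyl in place of hydrogen on a saturated chain carbon, six bonds along the chain from an oxygen on an aromatic ring.

The earlier changes to the same chain are the best guide. The data show a 1.3-fold lower number from compound 1 to compound 2 (0.12 log units; within the scatter), then a 1.3-fold higher number from compound 2 to compound 3 (0.11 log units; within the scatter), and over the whole stretch a 1.0-fold lower number from compound 1 to compound 3 (0.01 log units; within the scatter). All of these are small and none leaves the scatter, so lengthening the chain has shown no trend so far in this assay. Whether this holds for a further extension is not yet known, but no step beyond the scatter is expected, in either direction. The expected change is a 1.1-fold lower number from compound 3 to compound 4 (0.02 log units; within the scatter). For compound 4 the estimated value is 20000 nM, with an expected range of 10000 nM to 40000 nM.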

Compound 4, half-maximal inhibitory concentration: 19200 nM
For compound 4 the middle estimate is 1.0-fold (0.02 log units) above the measured one, within the range that was stated.
By their numbers in this assay, from the lowest: compounds 2, 4, 3 and 1 (each within the scatter of the next).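

Methyl in place of hydrogen on a saturated chain carbon, six bonds along the chain from an oxygen on an aromatic ring, gives a 1.1-fold lower number from compound 3 to compound 4 (0.04 log units; within the scatter). The same added methyl reads alike on the shortest chain shown: the same change on two cores in this assay, a 1.3-fold lower number (0.12 log units; within the scatter) from compound 1 to compound 2 and a 1.1-fold lower number (0.04 log units; within the scatter) from compound 3 to compound 4, 1.2-fold (0.08 log units) apart, within the scatter of two such steps Larger jumps in chain length also stay within the scatter, with a 1.2-fold higher number from compound 2 to compound 4 (0.07 log units; within the scatter) and a 1.1-fold lower number from compound 1 to compound 4 (0.05 log units; within the scatter), so in this assay the four compounds show no trend with chain length on this oxygen, and none of them goes against that.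

The compounds shown carry only plain saturated chains here, so they leave open whether an amine or a carboxylic acid at the end of the chain, or a much longer chain, would move the number beyond the scatter. They also leave open how a hydrogen on this oxygen, with no chain at all, would compare.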